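The source may hold more compounds than are shown below. What is called first, only, known or untested is meant among the compounds shown, and "the series" means these compounds.

Compound 1 `COc1ccc(/C=C/C(=O)c2ccccc2-c2ccc(F)cc2)cc1` is the reference point of this small series. In a functional assay on A549 cells (Homo sapiens) for antiproliferative activity, read by sulforhodamine B assay, with a stated time of 48 h (on this read-out higher numbers stand for weaker inhibition and lower numbers for stronger inhibition), compound 1 gives 140 nM. Among the measured compounds shown here, compound 2 `COc1ccc(/C=C/C(=O)c2ccccc2-c2ccc(F)nc2)cc1` differs from it by 6-fluoropyridin-3-yl in place of 4-fluorophenyl on an aromatic carbon, and in this assay compound 2 gives 930 nM; the single change therefore produced a 6.6-fold higher number from compound 1 to compound 2 (0.82 log units; beyond the scatter).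

Compound 3 `COc1ccc(C(=O)/C=C/c2ccccc2-c2ccc(F)cc2)cc1` is built from the same atoms as compound 1, joined differently, and the difference between the two cores is not broken down here. In this assay compound 3 gives 8200 nM, the highest of the three numbers, separated from compound 2 and from compound 1 by steps beyond the scatter.

Compound 4 `COc1ccc(C(=O)/C=C/c2ccccc2-c2ccc(F)nc2)cc1` stands to compound 3 as compound 2 stands to compound 1: it carries 6-fluoropyridin-3-yl in place of 4-fluorophenyl on an aromatic carbon. The place is described in the same words for both pairs, so this is the same change made on the other core. The expectation for compound 4 rests on one measured pair only and is carried over to a different core, so it is held loosely. Compound 4 is expected to give 45000 nM in this assay, with a plausible range from 12000 nM to 160000 nM. The expected step is a 5.5-fold higher number from compound 3 to compound 4 (0.74 log units; beyond the scatter), chosen because the same change gave a 6.6-fold higher number from compound 1 to compound 2 (0.82 log units; beyond the scatter) on the first core; whether the second core answers alike is not known until compound 4 is measured.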

Compound 4, half-maximal inhibitory concentration: > 50000 nM
Compound 4 ended at the assay's limit (the forecaster's own chance of this, stated with the estimate: 25%); middle value at least 1.1-fold (0.04 log units) away from the limit.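

Compound 4 gives > 50000 nM in this assay, which is a limit of the assay and not a number. Even so, putting 6-fluoropyridin-3-yl in place of 4-fluorophenyl gave an at least 6.0-fold higher number from compound 3 to compound 4 (0.78 log units; beyond the scatter), so on both cores shown the change moved the number the same way, towards weaker inhibition. This shows that the direction of the change carried over from one core to the other in these two pairs, but it does not show that the size carried over, and two pairs set no rule for any further core; the comparison stands as follows: the same change on two cores in this assay, a 6.6-fold higher number (0.82 log units; beyond the scatter) from compound 1 to compound 2 and an at least 6.0-fold higher number (0.78 log units; beyond the scatter) from compound 3 to compound 4; the limit leaves it open whether they differ.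

The compounds shown leave open how other aromatic groups would read at this place on the two cores, such as a pyridinyl group without fluorine or a chlorophenyl group, and whether any of them would keep the number of compound 1 or improve on it. They also leave open what would follow if the methoxy group, which all four compounds carry, gave way to a hydroxyl group, an amine or a carboxylic acid, and how far the true number of compound 4 lies from its limit.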